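Carbamoyl to sulfamoyl: what to expect for compound 3

This account rests on a few compounds, and the source may have more. Where it says the series, first, only, none or still open, it means among the compounds named here.

Measured so far in an assay for binding affinity to dual specificity mitogen-activated protein kinase kinase 4 (Homo sapiens), read by KINOMEscan, tested at 100 nM; on this read-out higher numbers stand for a weaker effect at the one concentration tested and lower numbers for a stronger effect:
compound 1, `CCCS(=O)(=O)Nc1ccc(F)c(C(=O)c2n[nH]c3ncc(-c4cccc(OC)c4)cc23)c1F`, gives 6.3%
compound 2, `CCCS(=O)(=O)Nc1ccc(F)c(C(=O)c2n[nH]c3ncc(-c4ccc(C(N)=O)cc4)cc23)c1F`, gives 0.15%

Both measured compounds leave only a small fraction of the kinase's activity at the single concentration tested, so both bind strongly. For the measured compounds named here, compound 2 stands next to compound 1 rather than apart from it: the one step known, a number 6.2 percentage points lower from compound 1 to compound 2 (within the scatter), cannot be told from repeat-measurement noise.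

Compound 3, `CCCS(=O)(=O)Nc1ccc(F)c(C(=O)c2n[nH]c3ncc(-c4ccc(S(N)(=O)=O)cc4C)cc23)c1F`, is not yet measured. It differs from compound 2 as follows: 2-methyl-4-sulfamoylphenyl in place of 4-carbamoylphenyl on an aromatic carbon. Going by the values given here, the only step that bears on this change is the earlier exchange of one aryl group for another, a number 6.2 percentage points lower from compound 1 to compound 2 (within the scatter), which was small. On that basis the new aryl group is expected to leave the result in the same low range, with no step beyond the scatter, so the expected change is a number 1.9 percentage points higher from compound 2 to compound 3 (within the scatter). Compound 3 is therefore estimated at 2%, within 0% to 15%.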

Compound 3, a percentage reported as activity, at one concentration (the size of the read-out at that concentration, not a potency): 3.1%
Beside the measured number, compound 3's estimate is 1.1 percentage points below it; the range from low to high includes it.
By their numbers in this assay, from the lowest: compounds 2, 3 and 1 (each within the scatter of the next).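

In this assay, this aromatic carbon also takes a phenyl ring carrying two changes at once, a sulfamoyl group in place of carbamoyl plus an added methyl: the exchange gives a number 3 percentage points higher from compound 2 to compound 3 (within the scatter) and, against the methoxy compound, a number 3.2 percentage points lower from compound 1 to compound 3 (within the scatter). Three different aryl groups at this place now give numbers that lie within the scatter of one another, so at this single concentration the read-out does not separate them. Nothing available explains why the result stays in this range.

From the compounds shown here alone, because the methyl and the sulfamoyl group enter together, the contribution of each alone remains unknown. The compounds shown also leave open whether a phenyl ring carrying a carboxylic acid or an amine at this place would stay in the same low range.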